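Triazolylmethyl steroid series: cytotoxicity readouts all at limit

The compounds below may be only part of what the source reports. "The series", "measured", "known", "first", "only" and "open" are said of these compounds alone.

Measured so far:
Compound 1 `Cc1c(O)ccc2c1[C@H](Cn1cc(-c3ccc(C(F)(F)F)cc3)nn1)[C@@]13CC(=O)[C@@](C)(CC[C@@H]21)C3`: in a functional assay on HL-60 cells (Homo sapiens) for cytotoxicity, read by MTT assay, with a stated time of 4 days (a higher number here means a weaker inhibitor, a lower number a stronger inhibitor), compound 1 gives > 20000 nM, a limit of the assay.
Compound 2 `Cc1ccc(-c2cn(C[C@H]3c4c(ccc(O)c4C)[C@@H]4CC[C@@]5(C)C[C@]43CC5=O)nn2)cc1`: in this assay compound 2 gives > 20000 nM, a limit of the assay.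
Compound 3 `Cc1ccc(-c2cn(C[C@H]3c4c(ccc(OS(=O)(=O)c5ccc(C)cc5)c4C)[C@@H]4CC[C@@]5(C)C[C@]43CC5=O)nn2)cc1`: in this assay compound 3 gives > 20000 nM, a limit of the assay.

Compound 1 differs from compound 2 by trifluoromethyl in place of methyl on an aromatic carbon. The step that the two limits leave unreadable from compound 2 to compound 1 cannot be sized because of the limit of > 20000 nM in this assay, at which 3 of the 3 values shown sit. Compound 3 differs from compound 2 by (4-methylphenyl)sulfonyl in place of hydrogen on an oxygen on an aromatic ring, and the step that the two limits leave unreadable from compound 2 to compound 3 is likewise not readable.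

Compound 4 `Cc1ccc(S(=O)(=O)Oc2ccc3c(c2C)[C@H](Cn2cc(-c4ccc(C(F)(F)F)cc4)nn2)[C@@]24CC(=O)[C@@](C)(CC[C@@H]32)C4)cc1` differs from compound 3 by trifluoromethyl in place of methyl on an aromatic carbon; this is the same change as that from compound 2 to compound 1, in the same place. For compound 4 in this assay a step that the limit leaves unreadable from compound 3 to compound 4 is expected, resting on a step that the two limits leave unreadable from compound 2 to compound 1 and on (the limit of > 20000 nM in this assay, at which 3 of the 3 values shown sit). Compound 4 is estimated at 30000 nM, with a range from 10000 nM to 100000 nM, and most likely reported only as a limit.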

Compound 4, half-maximal inhibitory concentration: > 20000 nM
Compound 4 ended at the assay's limit (the forecaster's own chance of this, stated with the estimate: 85%); the middle value is on the limit's open side.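

In this assay compound 4 gives > 20000 nM, a limit of the assay, so no step from compound 1 or compound 3 to compound 4 can be read: the limit of > 20000 nM in this assay, at which 4 of the 4 values shown sit.

Going by these compounds, whether trifluoromethyl in place of methyl or (4-methylphenyl)sulfonyl in place of hydrogen changes cytotoxicity at all remains open.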